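Changing the aryl group on a shared core

This account rests on a few compounds, and the source may have more. Where it says the series, first, only, none or still open, it means among the compounds named here.

Measured so far:
- compound 1, `c1ccc2c(-c3cn4ccnc4c(-c4ccc5ncn(C6CCCCC6)c5c4)n3)cccc2c1`, gives 9.08%
- compound 2, `Fc1ccc(-c2cn3ccnc3c(-c3ccc4ncn(C5CCCCC5)c4c3)n2)cc1`, gives 14.2%
- compound 3, `CC(=O)c1ccc(-c2cn3ccnc3c(-c3ccc4ncn(C5CCCCC5)c4c3)n2)cc1`, gives 3.96%

These numbers come from a functional assay on SNB-19 cells (Homo sapiens) for inhibition, read by sulforhodamine B assay, with a stated time of 48 h, tested at 10 uM; a lower number here means less inhibition, a higher number more inhibition at the concentration tested (going by the name of the read-out). Compound 2 has the largest of the three, but its gap to compound 1, a number 5.1 percentage points higher from compound 1 to compound 2 (within the scatter), lies within the scatter, so the two cannot be told apart; only compound 3 sits apart from it, a number 10.2 percentage points lower from compound 2 to compound 3 (beyond the scatter).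

Compound 4, `FC(F)(F)c1cccc(-c2cn3ccnc3c(-c3ccc4ncn(C5CCCCC5)c4c3)n2)c1`, differs from compound 2 in one place: 3-(trifluoromethyl)phenyl in place of 4-fluorophenyl on an aromatic carbon. The three earlier steps all change the same aryl group and bear on this one. Two of them, a number 5.1 percentage points higher from compound 1 to compound 2 (within the scatter) and a number 5.1 percentage points lower from compound 1 to compound 3 (within the scatter), stay within the scatter, and the third, a number 10.2 percentage points lower from compound 2 to compound 3 (beyond the scatter), is only modest. Swapping this aryl group has therefore moved the number little so far, and no step beyond the scatter is expected here either, a number 5.2 percentage points lower from compound 2 to compound 4 (within the scatter). Compound 4 is estimated at 9%, within a range from 0% to 20%.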

Compound 4, a percentage reported as inhibition, at one concentration (the size of the read-out at that concentration, not a potency): 2.24%
For compound 4 the middle estimate is 6.8 percentage points above the measured one; the measured number falls inside the stated range.
By their numbers in this assay, from the lowest: compounds 4, 3, 1 and 2 (each within the scatter of the next, the first and the last beyond it).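

In this assay, the change to 3-(trifluoromethyl)phenyl gives a number 12 percentage points lower from compound 2 to compound 4 (beyond the scatter), so a second aryl group, after the 4-acetylphenyl of compound 3, now stands apart from 4-fluorophenyl. The new group cannot be told apart from the other two, as shown by a number 1.7 percentage points lower from compound 3 to compound 4 (within the scatter) and a number 6.8 percentage points lower from compound 1 to compound 4 (within the scatter), and compound 1 remains within the scatter of all three other compounds. Nothing measured here explains why these aryl groups separate as they do.

The step from 4-fluorophenyl to 3-(trifluoromethyl)phenyl changes both the substituent and where it sits on the phenyl ring, so the compounds shown cannot separate those two changes. As far as these compounds go, how a phenyl ring carrying an amine or a carboxylic acid would read at this position also stays open.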